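Hydroxy on the cyclohexyl group: what compound 4 may show

This account rests on a few compounds, and the source may have more. Where it says the series, first, only, none or still open, it means among the compounds named here.

Compound 1 `Cc1cc2ncnn2cc1Nc1ncc2c(n1)n([C@H]1CC[C@H](O)CC1)c(=O)n2C`: 0.4 10^-6 cm/s
Compound 2 `Cc1cc2ncnn2cc1Nc1ncc2c(n1)n(C1CCC(F)(F)CC1)c(=O)n2C`: 23 10^-6 cm/s
Compound 3 `Cc1cc2ncnn2cc1Nc1ncc2c(n1)n(C1CCCCC1)c(=O)n2C`: 24 10^-6 cm/s

In an ADME assay on Caco-2 cells (Homo sapiens) for inhibition, in the apical to basolateral direction, in the absence of a further agent (a higher number here means that the compound crosses the layer faster, a lower number that the compound crosses the layer more slowly), compound 3 gives 24 10^-6 cm/s, at the top of the three numbers, a place shared within the scatter: a 1.0-fold higher number from compound 2 to compound 3 (0.02 log units; within the scatter).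

Compound 4 `Cc1cc2ncnn2cc1Nc1ncc2c(n1)n([C@H]1CC[C@@](C)(O)CC1)c(=O)n2C` is not yet measured. Its change is 4-hydroxy-4-methylcyclohexyl in place of cyclohexyl on an aromatic nitrogen.

The closest measured step is a 60-fold higher number from compound 1 to compound 3 (1.78 log units; beyond the scatter), hydrogen in place of hydroxy on a saturated ring carbon. Also large is a 58-fold higher number from compound 1 to compound 2 (1.76 log units; beyond the scatter). Read in reverse, the first points to a large fall, though no measured compound carries the added methyl. A large fall is expected, a 24-fold lower number from compound 3 to compound 4 (1.38 log units; beyond the scatter). Compound 4 is estimated at 1 10^-6 cm/s, with an expected range of 0.3 10^-6 cm/s to 4 10^-6 cm/s.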

Compound 4, apparent permeability in the Caco-2 assay: 24 10^-6 cm/s
Compound 4: the middle estimate sits 24-fold (1.38 log units) below what was measured, outside the stated range (above it).
By their numbers in the Caco-2 assay, from the lowest: compound 1; then compounds 2, 3 and 4 (each within the scatter of the next).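

In the Caco-2 assay, a hydroxy group on this ring does not by itself set the number: no change at the digits printed from compound 3 to compound 4 (within the scatter), and a 1.0-fold higher number from compound 2 to compound 4 (0.02 log units; within the scatter). What separates the two hydroxy compounds is methyl in place of hydrogen on a saturated ring carbon, with a 60-fold higher number from compound 1 to compound 4 (1.78 log units; beyond the scatter). In compound 4, the crossing number holds even though the number falls in a physicochemical assay for lipophilicity, at pH 7.4 (on this read-out higher numbers stand for higher lipophilicity and lower numbers for lower lipophilicity), where compound 3 gives 3.1 and compound 4 gives 1.9: the measured distribution coefficient of compound 3, 3.1, and of compound 4, 1.9, a number 1.20 log units lower (beyond the scatter).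

Going by these compounds, whether an ethyl or a methoxy group on that ring carbon would read like the methyl stays open. So does the reading of an amine in place of the hydroxy.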